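This account rests on a few compounds, and the source may have more. Where it says the series, first, only, none or still open, it means among the compounds named here.

Of the compounds shown here, three built on a shared core have been measured in a functional assay on CHO-K1 cells for antagonist activity at prostaglandin E2 receptor EP1 subtype (Homo sapiens), read by FLIPR; a lower number here means a stronger inhibitor, a higher number a weaker inhibitor. Compound 1 `O=C(O)c1ccnn1Cc1cc(Br)ccc1OCc1ccccc1` carries a 5-carboxy-1H-pyrazol-1-yl on a saturated chain carbon bound to an aromatic carbon. In this assay compound 1 gives < 2000 nM, which is a limit of the assay rather than a number. Compound 2 `O=C(O)c1cnn(Cc2cc(Br)ccc2OCc2ccccc2)c1` carries a 4-carboxy-1H-pyrazol-1-yl in that place. In this assay compound 2 gives < 2000 nM, again a limit. Compound 3 `O=C(O)c1cn(Cc2cc(Br)ccc2OCc2ccccc2)cn1` carries a 4-carboxy-1H-imidazol-1-yl there. In this assay compound 3 gives < 2000 nM, also a limit. Because all three values sit at the limit of < 2000 nM in this assay, at which 3 of the 3 values shown sit, the steps between them cannot be read: a step that the two limits leave unreadable from compound 1 to compound 2, a step that the two limits leave unreadable from compound 1 to compound 3 and a step that the two limits leave unreadable from compound 2 to compound 3. Compound 3 thus stands together with the other two at the limit, and nothing shows how it compares with them.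

Compound 4 `O=C(O)c1cn(Cc2cc(Br)ccc2OCc2ccccc2)nn1` differs from compound 3 by 4-carboxy-1H-1,2,3-triazol-1-yl in place of 4-carboxy-1H-imidazol-1-yl on a saturated chain carbon bound to an aromatic carbon. The three measured steps each swap one such five-membered ring for another in the same place, and every one left the value at the limit; none gives a readable size, so no particular direction is expected in this assay beyond the scatter. Compound 4 is therefore expected at 500 nM, within 50 nM to 2000 nM. The step this estimate implies is a step that the limit leaves unreadable from compound 3 to compound 4, expected most likely to end at the limit as well.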

Compound 4, inhibition constant: < 2000 nM
Compound 4 ended at the assay's limit (the forecaster's own chance of this, stated with the estimate: 70%); the middle value is on the limit's open side.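

Compound 4 joins compound 1, compound 2 and compound 3 at the same limit, so no step among these four compounds can be read: the limit of < 2000 nM in this assay, at which 4 of the 4 values shown sit. The compounds shown leave open how strongly each one actually inhibits in this assay, and whether swapping one carboxy-bearing five-membered ring for another changes that at all.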